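Trifluoromethyl Benzoate of a Shared Core: Expected Inhibition

A few compounds are considered here, and "the series" means these few. Any claim that something is new, unique, unknown or untested is made for them only; others in the source may bear on it.

Three esters on one shared core have been tested in a functional assay on MCF7 cells (Homo sapiens) for antiproliferative activity, read by sulforhodamine B assay, with a stated time of 48 h, tested at 50 uM; on this read-out lower numbers stand for less inhibition and higher numbers for more inhibition at the one concentration tested (going by the name of the read-out). Compound 1 `CC1=CC[C@H](C(C)C)c2cc(C)c(OC(=O)c3ccc([N+](=O)[O-])cc3)cc21` gives 72.9%, and compound 3 `CC1=CC[C@H](C(C)C)c2cc(C)c(OC(=O)c3ccc(Cl)cc3)cc21` gives 79.7%. Compound 2 `CC1=CC[C@H](C(C)C)c2cc(C)c(OC(=O)c3ccccc3)cc21`, the ester whose benzoate ring carries only hydrogen, gives 60.7%, the lowest of the three numbers, with compound 1 nearest to it and compound 3 furthest from it. The two steps that touch compound 2 both point the same way: a number 19 percentage points higher from compound 2 to compound 3 (beyond the scatter), and a number 12.2 percentage points lower from compound 1 to compound 2 (beyond the scatter), so that taking the nitro group away lowers the number while putting chloro in raises it. Compound 4 `CC1=CC[C@H](C(C)C)c2cc(C)c(OC(=O)c3cccc(C(F)(F)F)c3)cc21` differs from compound 2 by trifluoromethyl in place of hydrogen on an aromatic carbon. Among the measured compounds shown here, no measured step involves trifluoromethyl, and none involves a group at this place on the ring, so the chloro and nitro steps are the only guide. Both of those replacements of hydrogen raised inhibition by a modest amount beyond the scatter, and a rise of similar size is therefore expected here, though with wide uncertainty. For compound 4 the expected value in this assay is 72%, with a range from 58% to 86%. This corresponds to an expected step of a number 11.3 percentage points higher from compound 2 to compound 4 (beyond the scatter).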

Compound 4, a percentage reported as inhibition, at one concentration (the size of the read-out at that concentration, not a potency): 86%
The estimate for compound 4 lay 14 percentage points below the measured number; the measured number falls inside the stated range.
By their numbers in this assay, from the lowest: compound 2; then compounds 1, 3 and 4 (each within the scatter of the next, the first and the last beyond it).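

In this assay, among the compounds shown here, the benzoate ring accepts a substituent at a new place, since trifluoromethyl on an aromatic carbon meta to a large group gives a number 25.3 percentage points higher from compound 2 to compound 4 (beyond the scatter) and this is the first step to show a group at that place raising the number. With this result, each of the three substituted esters, compounds 1, 3 and 4, stands above the unsubstituted benzoate compound 2, and none of the compounds shown goes against this, so the rise is no longer tied to chloro, nitro or a single place on the ring. No measurement of any property of these esters is available to account for this rise.

Trifluoromethyl is seen at only one place and chloro and nitro at another, so the compounds shown cannot separate the contribution of the group from that of its place on the ring. They also leave open whether an amine, a carboxylic acid or a methoxy group at this same place would raise the number as well, or whether the rise extends to groups of other kinds.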